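A few compounds are considered here, and "the series" means these few. Any claim that something is new, unique, unknown or untested is made for them only; others in the source may bear on it.

Compound 1 `CCCCCCCCn1cc(COC2(C(F)(F)F)Oc3ccccc3C=C2C(=O)OCC)nn1` carries an octyl group on an aromatic nitrogen of its core and was examined in a functional assay on HeLa cells (Homo sapiens) for inhibition, read by MTT assay, with a stated time of 24 h; on this read-out lower numbers stand for stronger inhibition and higher numbers for weaker inhibition. In this assay compound 1 gives > 150000 nM, which is a limit of the assay and not a measured number. A second compound, compound 2 `O=C(O)C1=Cc2ccccc2OC1(OCc1cc(-c2ccc(F)cc2)no1)C(F)(F)F`, was examined in the same way. In this assay compound 2 gives > 150000 nM, again a limit rather than a number. Compound 1 therefore stands at the edge of what the assay reports, and all that the measured values show is summed up in one observation: the limit of > 150000 nM in this assay, at which 2 of the 2 values shown sit. Neither compound offers a number from which the effect of a change could be read.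

Compound 3 `CCOC(=O)C1=Cc2ccccc2OC1(OCc1cn(-c2ccc([N+](=O)[O-])cc2)nn1)C(F)(F)F` differs from compound 1 in one place: 4-nitrophenyl in place of octyl on an aromatic nitrogen. Among the compounds with values here, no step between two measured compounds is available for this change, so its size cannot be taken from the data. Because both measured values sit at the limit of > 150000 nM in this assay, at which 2 of the 2 values shown sit, nothing points to a gain within reach of the assay. The expected step is a step that the limit leaves unreadable from compound 1 to compound 3, none beyond the scatter. Compound 3 is thus estimated at about 200000 nM, between 50000 nM and 1000000 nM, and most likely reported again only as a limit.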

Compound 3, half-maximal inhibitory concentration: > 150000 nM
Compound 3: only a limit was reported; the forecaster's own chance of this, stated with the estimate: 75%; the middle value lies beyond the limit too.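

In this assay compound 3 gives > 150000 nM, again a limit and not a number. No step from compound 1 to compound 3 can therefore be read, and the evidence stays as it was: the limit of > 150000 nM in this assay, at which 3 of the 3 values shown sit.

The compounds shown leave open whether any group on the shared core can bring a readable number in this assay.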